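The source may hold more compounds than are shown below. What is called first, only, known or untested is meant among the compounds shown, and "the series" means these compounds.

Measured so far in a functional assay on A549 cells (Homo sapiens) for antiproliferative activity, read by MTT assay, with a stated time of 72 h; a higher number here means a weaker inhibitor, a lower number a stronger inhibitor:

Compound 1, `COc1ccc(-n2c(=O)c(C(=O)Nc3ccc(Oc4ccnc5[nH]ccc45)cc3)cc3cccnc32)cc1`, gives 930 nM.
Compound 2, `O=C(Nc1ccc(Oc2ccnc3[nH]ccc23)cc1)c1cc2cccnc2n(-c2ccc(F)c(Cl)c2)c1=O`, gives 680 nM.
Compound 3, `COc1ccc(-n2c(=O)c(C(=O)Nc3ccc(Oc4ccnc5c4ccn5C)c(F)c3)cc3cccnc32)cc1`, gives 2750 nM.

Compounds 1 and 2 share a core and differ in one place: 3-chloro-4-fluorophenyl in place of 4-methoxyphenyl on an aromatic nitrogen. This change made a step of a 1.4-fold lower number from compound 1 to compound 2 (0.14 log units; within the scatter), a step that does not separate the two compounds in this assay.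

Compound 3 stands apart: its value is the highest of the three, and the difference between its core and the core of compound 1 is not broken down here.

Compound 4, `Cn1ccc2c(Oc3ccc(NC(=O)c4cc5cccnc5n(-c5ccc(F)c(Cl)c5)c4=O)cc3F)ccnc21`, has not yet been measured. It is made from compound 3 by the same change: 3-chloro-4-fluorophenyl in place of 4-methoxyphenyl on an aromatic nitrogen. Since the group that leaves, the group that enters and the place where the change occurs are the same as those from compound 1 to compound 2, the same kind of step is expected.

Compound 4 is therefore estimated to sit close to compound 3, with an expected step of a 1.4-fold lower number from compound 3 to compound 4 (0.14 log units; within the scatter), resting on the small step of a 1.4-fold lower number from compound 1 to compound 2 (0.14 log units; within the scatter) seen on the other core. The estimate for compound 4 is 2000 nM, expected to lie between 900 nM and 4500 nM.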

Compound 4, half-maximal inhibitory concentration: 3560 nM
Estimate against measurement, compound 4: 1.8-fold (0.25 log units) below; the range from low to high includes it.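

In this assay, putting 3-chloro-4-fluorophenyl in place of 4-methoxyphenyl on the aromatic nitrogen gives a step of a 1.3-fold higher number from compound 3 to compound 4 (0.11 log units; within the scatter), which does not separate the two compounds. Set beside the earlier pair, the change does little on either core, and the two steps cannot be told apart: the same change on two cores in this assay, a 1.4-fold lower number (0.14 log units; within the scatter) from compound 1 to compound 2 and a 1.3-fold higher number (0.11 log units; within the scatter) from compound 3 to compound 4, 1.8-fold (0.25 log units) apart, within the scatter of two such steps. This supports carrying the swap from one of these cores to the other as a change with little effect in this assay, but two pairs cannot show that it would stay small on a further core, and they do not explain why it is small here.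

The compounds shown carry only these two substituted phenyl rings on that nitrogen, so it remains open whether a different group there, such as a simple alkyl chain, a pyridine ring or a phenyl ring bearing an amine or a carboxylic acid, would give a step beyond the scatter.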